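The compounds below may be only part of what the source reports. "The series", "measured", "known", "first", "only" and "open" are said of these compounds alone.

In a functional assay on THP-1 cells (Homo sapiens) for inhibition, read by sulforhodamine B assay, with a stated time of 48 h, tested at 50 uM (a higher number here means more inhibition of growth at the concentration tested, a lower number less inhibition of growth), compound 1 (`COc1cccc(/C=C/C(=O)/C=C/c2ccc(OCc3cn(CCCOc4cc(=O)oc5ccccc45)nn3)c(OC)c2)c1`) gives 58% while compound 2 (`COc1ccc(/C=C/C(=O)/C=C/c2ccc(OCc3cn(CCCOc4cc(=O)oc5ccccc45)nn3)c(OC)c2)cc1`) gives 56% and compound 3 (`COc1cc(/C=C/C(=O)/C=C/c2ccccc2)ccc1OCc1cn(CCCOc2cc(=O)oc3ccccc23)nn1`) gives 48% on the same shared core. These three numbers sit within the usual scatter of each other, so compound 3 stands level with the other two. Compound 4 (`COc1cc(/C=C/C(=O)/C=C/c2cccs2)ccc1OCc1cn(CCCOc2cc(=O)oc3ccccc23)nn1`) is compound 3 with thiophen-2-yl in place of phenyl on a double-bonded chain carbon bound to a double-bonded chain carbon and it has not yet been measured. Among the measured compounds shown here, no measured step exchanges one kind of ring for another at that place, so the evidence is only indirect. For the measured compounds named here, the one step at that same place, a shift of the methoxy group, is a number 2 percentage points lower from compound 1 to compound 2 (within the scatter) and it is small. The steps that put hydrogen in place of methoxy on that same ring are a number 10 percentage points lower from compound 1 to compound 3 (within the scatter) and a number 8 percentage points lower from compound 2 to compound 3 (within the scatter) and both stay inside the scatter as well. These steps offer no clear direction, so the expected step in this assay is a number 2 percentage points higher from compound 3 to compound 4 (within the scatter) and nothing beyond the scatter is anticipated. For compound 4 the estimate is 50% with 38% to 62% as the expected range.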

Compound 4, percent growth inhibition at one concentration: 54%
The estimate for compound 4 lay 4 percentage points below the measured number; low and high end bracket the measured number.
By their numbers in this assay, from the lowest: compounds 3, 4, 2 and 1 (each within the scatter of the next).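

In this assay, among the compounds shown here, thiophen-2-yl in place of phenyl on a double-bonded chain carbon bound to a double-bonded chain carbon is the first step that exchanges one kind of ring for another at this place, and it reads as a number 6 percentage points higher from compound 3 to compound 4 (within the scatter) in the comparison of these two neighbours. The methoxy-bearing rings give the same picture, with thiophen-2-yl in place of 4-methoxyphenyl reading as a number 2 percentage points lower from compound 2 to compound 4 (within the scatter) and thiophen-2-yl in place of 3-methoxyphenyl as a number 4 percentage points lower from compound 1 to compound 4 (within the scatter), so this five-membered ring with its sulfur atom stands level with all three six-membered rings in this read-out. Nothing shown here explains the numbers at this place, so no reason can be attached to them.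

Every group shown at this place is a flat aromatic ring, which leaves open what a saturated ring such as cyclohexyl, a ring bearing an amine or a carboxylic acid, or a pyridine ring would do. Also open is whether any change at this place can move growth inhibition beyond the usual scatter, since none of the steps shown does so.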